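The compounds below may be only part of what the source reports. "The series", "measured", "known", "first", "only" and "open" are said of these compounds alone.

Working notes on the series. Compound 1 `COc1cc(N(C)CCCO)ccc1/C=C1\C(=O)N(C2CCCCC2)C(=S)N1C`, compound 2 `COc1cc(N(C)CCCO)ccc1/C=C1\C(=O)N(c2ccccc2)C(=S)N1C` and compound 3 `CN1C(=S)N(C2CCCCC2)C(=O)/C1=C\c1ccc(N(C)C)cc1O` have been measured; compound 4 `CN1C(=S)N(c2ccccc2)C(=O)/C1=C\c1ccc(N(C)C)cc1O` has not.

In an assay on isolated protein for inhibition of NADPH oxidase 2 (Homo sapiens), read by chemiluminescence, in the presence of a further agent that is not named here (on this read-out higher numbers stand for weaker inhibition and lower numbers for stronger inhibition), compound 1 gives 990 nM. In this assay compound 2 gives 2790 nM, and compound 3 gives 2960 nM. The numbers for compound 2 and compound 3 lie within the scatter of each other, so no order between them is claimed. Compound 1 stands apart from both, its steps to compound 2 and to compound 3 being beyond the scatter.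

Among the measured compounds shown here, the single change between compound 1 and compound 2 is phenyl in place of cyclohexyl on an amide-type nitrogen in a ring. In this assay it gives a 2.8-fold higher number from compound 1 to compound 2 (0.45 log units; beyond the scatter).

Compound 4 arises from compound 3 by phenyl in place of cyclohexyl on an amide-type nitrogen in a ring. The place description for this pair reads word for word as for the first pair, so it is the same change, made on a different core. How the core of compound 1 differs from the core of compound 3 is not broken down here.

Expectation. With one measured instance of the change, the forecast rests on the step of a 2.8-fold higher number from compound 1 to compound 2 (0.45 log units; beyond the scatter), carried over to the pair that shares the same change. On that basis the expected step is a 2.8-fold higher number from compound 3 to compound 4 (0.45 log units; beyond the scatter), and its range is given extra width. In this assay compound 4 is therefore estimated at 8300 nM. For compound 4 the expected range runs from 4000 nM to 17000 nM.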

Compound 4, half-maximal inhibitory concentration: 3730 nM
Estimate against measurement, compound 4: 2.2-fold (0.35 log units) above; measured number below the stated range.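

In this assay, phenyl in place of cyclohexyl on an amide-type nitrogen in a ring gives a 1.3-fold higher number from compound 3 to compound 4 (0.10 log units; within the scatter), so on this core the change does not separate the two compounds. Set beside the earlier step, this result does not establish a difference between the two cores: the same change on two cores in this assay, a 2.8-fold higher number (0.45 log units; beyond the scatter) from compound 1 to compound 2 and a 1.3-fold higher number (0.10 log units; within the scatter) from compound 3 to compound 4, 2.2-fold (0.35 log units) apart, within the scatter of two such steps. Among the compounds shown here, the two steps are therefore compatible with a single step of similar size on both cores, but they show neither that the change carries over unchanged nor that its size depends on the core, since only one of the two steps lies beyond the scatter and only two pairs are available.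

The compounds shown carry only cyclohexyl and phenyl on this nitrogen, so it remains open how a benzyl group, a pyridine ring or a short alkyl chain would read there on either core. Also open, going by these compounds, is whether the same comparison would hold on a third core, for instance one carrying a carboxylic acid or a longer amine chain, where a further pair could help show whether the step stays within the scatter or moves beyond it.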